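The source may hold more compounds than are shown below. What is called first, only, known or untested is meant among the compounds shown, and "the series" means these compounds.

In a functional assay on A549 cells (Homo sapiens) for inhibition, read by MTT assay, with a stated time of 72 h (on this read-out lower numbers stand for stronger inhibition and higher numbers for weaker inhibition), three compounds sharing one core have been measured. Compound 1 (`COc1cc(/C=C/C(=O)c2c(OC)cc(O)c(CC=C(C)C)c2O)ccc1O`) gives 11800 nM, compound 2 (`COc1ccc(/C=C/C(=O)c2c(OC)cc(O)c(CC=C(C)C)c2O)cc1OC`) gives 15700 nM, and compound 3 (`COc1cc(O)c(CC=C(C)C)c(O)c1C(=O)/C=C/c1ccc(C(F)(F)F)cc1`) gives 11100 nM. Compound 1 therefore has no clear place of its own on these numbers, since it lies within the usual scatter of both other compounds.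

The step to compound 4 (`COc1cc(O)c(CC=C(C)C)c(O)c1C(=O)/C=C/c1cccc([N+](=O)[O-])c1`) is 3-nitrophenyl in place of 4-hydroxy-3-methoxyphenyl on a double-bonded chain carbon bound to a double-bonded chain carbon. In words, 3-nitrophenyl stands in place of 4-hydroxy-3-methoxyphenyl on a double-bonded chain carbon bound to a double-bonded chain carbon.

Going by the values given here, no measured compound carries a nitro group, so the evidence is indirect. Among the compounds with values here, the one measured step, a 1.3-fold higher number from compound 1 to compound 2 (0.12 log units; within the scatter), places methyl in place of hydrogen on an oxygen on an aromatic ring, and it stays within the scatter. Compound 3, which carries a trifluoromethyl group, gives 11100 nM, a value within the scatter of compound 1 at 11800 nM. Three compounds are a thin basis, but neither comparison shows a change of any size, so no shift beyond the scatter is expected. The expected step in this assay is a 1.1-fold lower number from compound 1 to compound 4 (0.03 log units; within the scatter). For compound 4, the estimated value is 11000 nM, with an expected range from 5500 nM to 22000 nM.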

Compound 4, half-maximal inhibitory concentration: 15000 nM
Compound 4: the middle estimate sits 1.4-fold (0.13 log units) below what was measured, within the range that was stated.
By their numbers in this assay, from the lowest: compounds 3, 1, 4 and 2 (each within the scatter of the next).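

At the place on a double-bonded chain carbon bound to a double-bonded chain carbon, this assay gives a 1.3-fold higher number from compound 1 to compound 4 (0.10 log units; within the scatter) when 3-nitrophenyl stands in place of 4-hydroxy-3-methoxyphenyl. The earlier single-place step changed only a methyl on an oxygen on an aromatic ring, whereas here the whole group is exchanged: the hydrogen-bond donor of 4-hydroxy-3-methoxyphenyl leaves, a nitrogen enters, the entering group has no donor, and the step still stays within the scatter. Nothing available bears on what lies behind this result.

The compounds shown therefore leave open whether any group at this place can move the number beyond the scatter, for instance an aminophenyl group, a carboxylic acid on the phenyl ring or a longer chain in place of the ring. They also leave open whether 4-nitrophenyl would behave as 3-nitrophenyl does, and whether a change elsewhere on the shared core, such as in the chain carrying the double bond, would matter more than the exchange at this place.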